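This account rests on a few compounds, and the source may have more. Where it says the series, first, only, none or still open, it means among the compounds named here.

Measured compounds in an assay on cells for displacement of a labelled ligand from adenosine receptor A2b (Homo sapiens), read by scintillation counting and radioligand binding, with a stated time of 30 min, tested at 10 uM; a lower number here means less inhibition, a higher number more inhibition at the concentration tested (going by the name of the read-out):
- compound 1, `Cn1cnc2c(N3CCCCC3)nc(-c3ccccc3O)nc21`, gives 30.2%
- compound 2, `Cn1cnc2c(N3CCCCC3)nc(-c3cc(Cl)ccc3Cl)nc21`, gives 31%
- compound 3, `Clc1cccc(-c2nc(N3CCCCC3)c3nc[nH]c3n2)c1`, gives > 80%, which is a limit of this assay rather than a number.

Compound 3 therefore stands at the upper limit: the assay reports only that its inhibition reached the top of what is resolved, as noted in the limit of > 80% in this assay, at which 1 of the 3 values shown sits. For the measured compounds named here, compounds 1 and 2 sit far lower, and the one measured step between them, a number 0.8 percentage points higher from compound 1 to compound 2 (within the scatter), concerns a change on the phenyl ring and not on the shared core.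

Compound 4, `Cn1cnc2c(N3CCCCC3)nc(-c3cccc(Cl)c3)nc21`, is compound 3 with a single change: methyl in place of hydrogen on an aromatic nitrogen. Going by the values given here, no measured step addresses a change at this aromatic nitrogen, since compounds 1 and 2 both carry the methyl and differ from compound 3 in their phenyl substituent as well. The expectation for compound 4 is therefore uncertain: the methylated compounds 1 and 2 lie well below the limit reached by compound 3, but that gap cannot be assigned to the methyl alone. A fall of about a number at least 30 percentage points lower from compound 3 to compound 4 (beyond the scatter) is estimated, with wide uncertainty.

Compound 4 is expected to give roughly 50% in this assay, within a range from 20% to 80%.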

Compound 4, a percentage reported as inhibition, at one concentration (the size of the read-out at that concentration, not a potency): 24.2%
Estimate against measurement, compound 4: 25.8 percentage points above, and the stated range covers the measured number.
By their numbers in this assay, from the lowest: compounds 4, 1 and 2 (each within the scatter of the next). At a limit, above all of these: compound 3.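

In this assay compound 3 gives > 80%, which is a limit and not a number: the limit of > 80% in this assay, at which 1 of the 4 values shown sits. For the compounds shown here, with 3-chlorophenyl kept in place, the methyl on the aromatic nitrogen is the only difference, and the result is a number at least 55.8 percentage points lower from compound 3 to compound 4 (beyond the scatter), which shows for the first time that this one added carbon on the five-membered ring can by itself take a compound from the limit down to the level of the other methylated compounds. Among those methylated compounds the phenyl substituent does not separate the values, with a number 6.8 percentage points lower from compound 2 to compound 4 (within the scatter) and a number 6 percentage points lower from compound 1 to compound 4 (within the scatter).

As far as these compounds go, it remains open how other groups on this nitrogen would behave, for example ethyl, a longer chain or a chain ending in an amine, and whether any of them would fall between hydrogen and methyl. From the compounds shown here alone, it is also open whether the 2-hydroxyphenyl and 2,5-dichlorophenyl groups would reach the same limit as 3-chlorophenyl when hydrogen sits on the nitrogen.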